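A few compounds are considered here, and "the series" means these few. Any claim that something is new, unique, unknown or untested is made for them only; others in the source may bear on it.

Measured compounds:
- compound 1, `COc1cc(NC(C)CCCNC(=O)NNC(=O)/C=C/c2ccccc2)c2ncccc2c1`: 13900 nM
- compound 2, `COc1cc(NC(C)CCCNC(=O)NNC(=O)/C=C/c2ccc(OC)c(OC)c2)c2ncccc2c1`: 37000 nM
- compound 3, `COc1cc(NC(C)CCCNC(=O)NNC(=O)/C=C/c2ccc(Cl)cc2)c2ncccc2c1`: 7300 nM

These three share one core and differ only in the ring at the end of the double-bonded chain. In an ADME assay on L6 cells (Rattus norvegicus) for cytotoxicity, read by resazurin assay, with a stated time of 70 h (on this read-out higher numbers stand for weaker inhibition and lower numbers for stronger inhibition), compound 3 sits at the low end of the three numbers; its gap to compound 1 is within the scatter, so those two cannot be told apart, while its gap to compound 2 is real, as the step of a 5.1-fold lower number from compound 2 to compound 3 (0.70 log units; beyond the scatter) shows.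

Compound 4, `COc1cc(NC(C)CCCNC(=O)NNC(=O)/C=C/c2cccc(C(F)(F)F)c2)c2ncccc2c1`, is the next variation: 3-(trifluoromethyl)phenyl in place of 4-chlorophenyl on a double-bonded chain carbon bound to a double-bonded chain carbon. Among the measured compounds shown here, no measured step involves a trifluoromethyl group. For the measured compounds named here, the steps that bear on it all concern this same ring position: a 1.9-fold lower number from compound 1 to compound 3 (0.28 log units; within the scatter) and a 2.7-fold higher number from compound 1 to compound 2 (0.43 log units; beyond the scatter). Swapping the substituent on this ring moved the number only modestly, and a single added group stayed within the scatter. A step within the scatter, or at most a modest one in either direction, is therefore expected in this assay.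

Compound 4 is estimated to give 8500 nM, with a range from 3000 nM to 25000 nM. That estimate means an expected step of a 1.2-fold higher number from compound 3 to compound 4 (0.07 log units; within the scatter).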

Compound 4, half-maximal inhibitory concentration: 10600 nM
Estimate against measurement, compound 4: 1.2-fold (0.10 log units) below; low and high end bracket the measured number.
By their numbers in this assay, from the lowest: compounds 3, 4 and 1 (each within the scatter of the next); then compound 2.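

In this assay, among the compounds shown here, trifluoromethyl is a larger added group than chloro, yet adding it to the phenyl ring still gives no step that can be told apart from the scatter, with a 1.3-fold lower number from compound 1 to compound 4 (0.12 log units; within the scatter) as the measured change. Replacing 4-chlorophenyl with 3-(trifluoromethyl)phenyl also stays within the scatter, at a 1.5-fold higher number from compound 3 to compound 4 (0.16 log units; within the scatter), so this position tolerates two different single groups, placed differently on the ring, with no readable change in the number. Compound 2 now stands apart from all three others, and a 3.5-fold lower number from compound 2 to compound 4 (0.54 log units; beyond the scatter) adds a further step beyond the scatter, so among these four only the 3,4-dimethoxyphenyl ring shifts the number.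

Nothing measured here explains why these rings behave as they do. Still open, going by these compounds, is whether an amine or a carboxylic acid on this ring would move the number any further.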